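Working notes: nitro in place of fluoro

A few compounds are considered here, and "the series" means these few. Any claim that something is new, unique, unknown or untested is made for them only; others in the source may bear on it.

compound 1 `O=S(=O)(NCCNC(=S)Nc1cccc(Cl)c1)c1ccc(-c2ccccc2OCc2ccccc2)s1` gives > 50000 nM (a limit)
compound 2 `O=C(Nc1ccc(F)cc1)N1CCN(S(=O)(=O)c2sccc2-c2ccccc2Oc2ccc(O)c(O)c2)CC1` gives 6800 nM

Both entries come from a functional assay on RS4-11 cells (Homo sapiens) for inhibition, read by CCK-8 assay, with a stated time of 48 h (a higher number here means a weaker inhibitor, a lower number a stronger inhibitor), and share little beyond a sulfonyl-linked aromatic portion. Compound 1 sits at the limit > 50000 nM and so gives no number. Among the compounds with values here, compound 2 at 6800 nM holds the only true number so far, so there is no ranking to read from it.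

Compound 3 `O=C(Nc1ccc([N+](=O)[O-])cc1)N1CCN(S(=O)(=O)c2sccc2-c2ccccc2Oc2ccc(O)c(O)c2)CC1` keeps everything in compound 2 except one group, with nitro in place of fluoro on an aromatic carbon, para to a large group nitro in place of fluoro on an aromatic carbon as the full count of the change.

Within the data shown here, no measured step bears on this change, so the expectation rests on compound 2 at 6800 nM alone. The expected move a 1.1-fold lower number from compound 2 to compound 3 (0.05 log units; within the scatter) stays within the usual scatter of this assay and favours no direction. Compound 3 is estimated at 6000 nM with an expected range from 2500 nM to 15000 nM as its span.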

Compound 3, half-maximal inhibitory concentration: 14300 nM
Compound 3: middle estimate off by 2.4-fold (0.38 log units), on the low side; the measured number falls inside the stated range.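

Within the data shown here, the change from 4-fluorophenyl to 4-nitrophenyl gives the first comparison that differs in one place, and in this assay it reads as a 2.1-fold higher number from compound 2 to compound 3 (0.32 log units; beyond the scatter) and so shows that the number responds to the group on this aromatic carbon, para to a large group. The step is modest and comes from a single pair, so it describes these two groups only and sets no trend for the position. No measurement shown accounts for the step.

Still open, going by these compounds, is where a methoxy group, an amine or a carboxylic acid at this position would fall relative to compound 2 in this assay and whether any of them would give a lower number. Also open, on these data alone, is whether nitro in place of fluoro would give a step of similar size elsewhere on this ring.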